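The source may hold more compounds than are shown below. What is called first, only, known or untested is meant among the compounds shown, and "the series" means these compounds.

Measured in a functional assay on PC-3 cells (Homo sapiens) for cytotoxicity, read by MTT assay; on this read-out lower numbers stand for stronger inhibition and higher numbers for weaker inhibition:
- Compound 1 (`COc1cccc(CSc2nnc([C@@H](C)c3ccc4cc(OC)ccc4c3)n2-c2ccc(Cl)cc2)c1`): 138000 nM
- Compound 2 (`COc1ccc2cc([C@H](C)c3nnc(SCc4ccc(F)cc4)n3-c3ccc(Cl)cc3)ccc2c1`): 10800 nM

Within the data shown here, of these two compounds, compound 2 has the lower number, 10800 nM, and compound 1 is its only neighbour. Compound 3 (`COc1ccc2cc([C@H](C)c3nnc(SCc4ccccc4)n3-c3ccc(Cl)cc3)ccc2c1`) has not yet been measured in this assay. It departs from compound 2 in one place: hydrogen in place of fluoro on an aromatic carbon, para to a large group.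

Among the measured compounds shown here, only one measured step bears on this change: a 13-fold lower number from compound 1 to compound 2 (1.11 log units; beyond the scatter), a large step beyond the scatter, with 4-fluorophenyl in place of 3-methoxyphenyl. For the measured compounds named here, that step exchanged one substituted group for another, so it does not isolate the fluoro, and no measured pair differs by the fluoro alone. Compound 3 carries neither substituent, so a much smaller change than that step is expected, probably leaning towards a higher number. The expected change is a 1.7-fold higher number from compound 2 to compound 3 (0.22 log units; within the scatter). Compound 3 is estimated at 18000 nM, with an expected range of 6500 nM to 60000 nM.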

Compound 3, half-maximal inhibitory concentration: 14200 nM
For compound 3 the middle estimate is 1.3-fold (0.10 log units) above the measured one; the measured number falls inside the stated range.
By their numbers in this assay, from the lowest: compounds 2 and 3 (each within the scatter of the next); then compound 1.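

In this assay, taking the fluoro away leaves the number within the scatter, with a 1.3-fold higher number from compound 2 to compound 3 (0.12 log units; within the scatter), so at this place on the ring the fluoro cannot be told apart from hydrogen. The earlier step had exchanged two substituted groups at once, and the unsubstituted benzyl compound now separates them: a 9.7-fold lower number from compound 1 to compound 3 (0.99 log units; beyond the scatter), a step beyond the scatter, shows that most of the difference between compound 1 and compound 2 goes with the loss of the methoxy group rather than with the gain of the fluoro, and compound 1 alone stands apart from the other two. Nothing available gives a reason for either result.

The compounds shown leave open whether the methoxy group would have the same effect on the phenyl ring if it sat para to the large group, since the fluoro and the methoxy do not occupy the same place in these compounds. Going by these compounds, it also remains unknown whether an amine, a carboxylic acid or a trifluoromethyl group at that para place would stay as close to hydrogen as the fluoro does.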